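The source may hold more compounds than are shown below. What is called first, only, known or untested is meant among the compounds shown, and "the series" means these compounds.

Of the compounds shown here, three have so far been measured in a functional assay on HCT-116 cells (Homo sapiens) for antiproliferative activity, read by MTT assay, with a stated time of 72 h; on this read-out lower numbers stand for stronger inhibition of growth and higher numbers for weaker inhibition of growth. Compound 1 `c1ccc(Cn2c(Nc3ccccc3)nc3cccnc32)cc1` gives 60200 nM. For the measured compounds named here, compound 2 `Cn1nc(-c2ccnc(Nc3ccc(S(N)(=O)=O)cc3)n2)c2ccccc21` gives 2280 nM, and compound 3 `CCn1nc(-c2ccnc(Nc3ccc(S(N)(=O)=O)cc3)n2)c2ccccc21` gives 2050 nM, the lowest of the three numbers; its gap to compound 1 lies beyond the usual scatter, whereas the only single-change step measured, a 1.1-fold lower number from compound 2 to compound 3 (0.05 log units; within the scatter), lies within it. Compound 4 `CCn1nc(-c2ccnc(Nc3ccc(O)cc3)n2)c2ccccc21` differs from compound 3 by hydroxy in place of sulfamoyl on an aromatic carbon. Going by the values given here, no measured step involves an exchange of this kind, so the one measured step offers no direct guide, and the expectation rests on the change itself. In this assay compound 4 is expected to give 6000 nM, with a range from 1500 nM to 25000 nM, an estimated step of a 2.9-fold higher number from compound 3 to compound 4 (0.47 log units; beyond the scatter) toward weaker growth inhibition.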

Compound 4, concentration for 50% growth inhibition: 5290 nM
For compound 4 the middle estimate is 1.1-fold (0.05 log units) above the measured one; low and high end bracket the measured number.
By their numbers in this assay, from the lowest: compounds 3 and 2 (each within the scatter of the next); then compound 4; then compound 1.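

Replacing sulfamoyl with hydroxy at this position, on an aromatic carbon para to a large group, gives a modest loss of growth inhibition, with a 2.6-fold higher number from compound 3 to compound 4 (0.41 log units; beyond the scatter). Sulfamoyl is therefore not required for activity in the micromolar range, although the smaller hydroxy group does not fully match it here. No available evidence accounts for this step. As far as these compounds go, it remains open whether an amine or a carboxylic acid at this position would fall nearer compound 3 or compound 4. From the compounds shown here alone, it is also open whether the same exchange on compound 2 would produce a similar step.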